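Ethyl to Isobutyl on the Core Nitrogen

A few compounds are considered here, and "the series" means these few. Any claim that something is new, unique, unknown or untested is made for them only; others in the source may bear on it.

Compound 1 `CCn1nc(S(=O)(=O)c2cccc3ccccc23)c2cc(N3CCN(C)CC3)ccc21`: 1.7 nM in a functional assay on HeLa cells for antagonist activity at 5-hydroxytryptamine receptor 6 (Homo sapiens); a higher number here means a weaker inhibitor, a lower number a stronger inhibitor
Compound 2 `COc1ccc(S(=O)(=O)c2n[nH]c3ccc(N4CCN(C)CC4)cc23)cc1`: 544 nM in this assay
Compound 3 `Cn1nc(S(=O)(=O)c2ccccc2)c2cc(N3CCNCC3)ccc21`: 3.2 nM in this assay

Compound 1 has the lowest of the three numbers. Compound 3 stands within the scatter of it, while compound 2 lies far beyond the scatter above it. Compound 4 `CC(C)Cn1nc(S(=O)(=O)c2cccc3ccccc23)c2cc(N3CCN(C)CC3)ccc21` differs from compound 1 in one place: isopropyl in place of methyl on a saturated chain carbon bound to an aromatic nitrogen. For the measured compounds named here, no measured pair shows this change, so its effect has to be judged from compound 1 alone. A small shift is expected, if any, and compound 4 is estimated to give 3 nM in this assay, within 1 nM to 10 nM. The expected step of a 1.8-fold higher number from compound 1 to compound 4 (0.25 log units; within the scatter) is small, possibly not beyond the scatter.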

Compound 4, half-maximal inhibitory concentration: 1.4 nM
Estimate against measurement, compound 4: 2.1-fold (0.33 log units) above, within the range that was stated.
By their numbers in this assay, from the lowest: compounds 4, 1 and 3 (each within the scatter of the next, the first and the last beyond it); then compound 2.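

Isopropyl in place of methyl on a saturated chain carbon bound to an aromatic nitrogen gives a 1.2-fold lower number from compound 1 to compound 4 (0.08 log units; within the scatter) in this assay. For the compounds shown here, this is the first single-place comparison, and it shows that going from ethyl to isobutyl, with 3 heavy atoms entering where 1 leaves, does not separate the two compounds in this read-out. No measurement shown accounts for this result. Open, from the compounds shown here alone, is whether the same position would take an amine, a carboxylic acid or a longer chain as it takes isobutyl.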